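Ester to Acid on a Purine Amide Series

The source may hold more compounds than are shown below. What is called first, only, known or untested is meant among the compounds shown, and "the series" means these compounds.

Measured so far:
compound 1 `O=C(CN(c1nc(Cl)nc2[nH]cnc12)C1CC1)N[C@@H](CO)C(=O)O`: 39.8%
compound 2 `NC(=O)CC[C@H](NC(=O)CN(c1nc(Cl)nc2[nH]cnc12)C1CC1)C(=O)OCc1ccccc1`: 33.1%

In a functional assay on the whole organism (Tail, strain ICR) with Mus musculus as the target, in the tail flick test, with a stated time of 60 min, at a dose of 25 umol/kg by the oral route (on this read-out higher numbers stand for a stronger effect at the one dose given and lower numbers for a weaker effect), compound 1 gives 39.8%, and in the same test compound 2 gives 33.1%. Within the data shown here, the two numbers lie within the usual scatter of each other, so the data show no separation between compound 1 and compound 2; no single-change step between measured compounds is available.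

Compound 3 `NC(=O)CC[C@H](NC(=O)CN(c1nc(Cl)nc2[nH]cnc12)C1CC1)C(=O)O` has not been measured. The change from compound 2 is hydrogen in place of benzyl on an oxygen next to a carbonyl group. The benzyl ester of compound 2 is thereby opened to the free acid, as compound 1 also carries a free acid.

Among the measured compounds shown here, with only two compounds in hand, both giving close results, the expected step from compound 2 to compound 3 is a number 3.9 percentage points higher from compound 2 to compound 3 (within the scatter), no larger than the scatter. Compound 3 is therefore estimated at 37%, with a range from 22% to 52%.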

Compound 3, a percentage reported as activity, at one dose (the size of the read-out at that dose, not a potency): 38.4%
Estimate against measurement, compound 3: 1.4 percentage points below; low and high end bracket the measured number.
By their numbers in this assay, from the lowest: compounds 2, 3 and 1 (each within the scatter of the next).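

In this assay, opening the benzyl ester to the free acid, with hydrogen in place of benzyl on an oxygen next to a carbonyl group, gives a number 5.3 percentage points higher from compound 2 to compound 3 (within the scatter), so this read-out does not separate the benzyloxycarbonyl and carboxy forms. With the free acid present, carbamoylmethyl in place of hydroxy on the saturated chain carbon gives a number 1.4 percentage points lower from compound 1 to compound 3 (within the scatter), so this side-chain change shows no separation either. Nothing measured here accounts for either result.

As far as these compounds go, it remains open whether a methyl ester or a primary amide at the carboxy position, or a longer chain or an amine in place of the carbamoylmethyl group, would stay in this range. With only one dose tested, the compounds also remain uncompared across a range of doses.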